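The compounds below may be only part of what the source reports. "The series", "measured", "known", "first", "only" and "open" are said of these compounds alone.

Measured in an ADME assay on BHK-21 cells (Mesocricetus auratus) for cytotoxicity, read by MTT assay, with a stated time of 120 h; a lower number here means that less compound is tolerated, a higher number that more compound is tolerated:
- compound 1 `O=C1C2=C(SCCS2)C(=O)N1CC(O)CN1CCN(c2ccc(F)cc2)CC1`: > 100000 nM (a limit)
- compound 2 `COc1ccccc1N1CCN(CC(O)CN2C(=O)C3=C(SCCS3)C2=O)CC1`: > 100000 nM (a limit)

Compound 1 is known only as a limit, > 100000 nM, and has no numerical value. Among the measured compounds shown here, the series so far stands at the limit of > 100000 nM in this assay, at which 2 of the 2 values shown sit. Nothing in these data shows how far either compound lies from that limit.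

Compound 3 `O=C1C2=C(SCCS2)C(=O)N1CCCN1CCN(c2ccc(F)cc2)CC1` departs from compound 1 by a single change: hydrogen in place of hydroxy on a saturated chain carbon bound to two saturated chain carbons.

For the measured compounds named here, no measured step covers this change. Going by the values given here, the only measured step, a step that the two limits leave unreadable from compound 1 to compound 2, has no readable size and concerns a different place in the structure, so it gives little guidance. No step beyond the usual scatter is therefore expected in this assay, and no direction can be assigned. The expected step is a number no higher from compound 1 to compound 3 (the limit leaves the size open), and a further limit is the likeliest report. For compound 3 the estimated value is 100000 nM, with an expected range from 40000 nM to 250000 nM.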

Compound 3, half-maximal cytotoxic concentration: > 100000 nM
Compound 3: only a limit was reported; the forecaster's own chance of this, stated with the estimate: 70%; the middle value sits exactly at the limit.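

Compound 3 is reported only as a limit in this assay, as is compound 1, so no step from compound 1 to compound 3 can be read: the limit of > 100000 nM in this assay, at which 3 of the 3 values shown sit.

The compounds shown leave open how far each lies from that limit, and whether hydrogen in place of hydroxy changes the tolerated concentration at all.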